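Swapping a difluorophenyl ring for a pentyl chain

A few compounds are considered here, and "the series" means these few. Any claim that something is new, unique, unknown or untested is made for them only; others in the source may bear on it.

- compound 1 `COc1cc(Cn2c(=O)cc(N3CCC[C@@H](N)C3)n(Cc3cc(F)ccc3C#N)c2=O)c(Br)c(Br)c1OC` gives 4.32
- compound 2 `Cc1cc(C)cc(Cn2c(=O)cc(N3CCC[C@@H](N)C3)n(Cc3cc(F)ccc3C#N)c2=O)c1` gives 3.89
- compound 3 `N#Cc1ccc(F)cc1Cn1c(N2CCC[C@@H](N)C2)cc(=O)n(Cc2cc(F)cc(F)c2)c1=O` gives 3.23

These are readings in a physicochemical assay for lipophilicity (a lower number here means a more polar compound, a higher number a more lipophilic compound), and compound 3 stands lowest of the three (3.23). Compound 4 `CCCCCCn1c(=O)cc(N2CCC[C@@H](N)C2)n(Cc2cc(F)ccc2C#N)c1=O` has not been measured yet. Its difference from compound 3 is pentyl in place of 3,5-difluorophenyl on a saturated chain carbon bound to an aromatic nitrogen.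

All three measured steps change the group at this same place. The modest step of a number 0.66 log units lower from compound 2 to compound 3 (beyond the scatter) and the large step of a number 1.09 log units lower from compound 1 to compound 3 (beyond the scatter) both end at compound 3, and the modest step of a number 0.43 log units lower from compound 1 to compound 2 (beyond the scatter) links the other two. Each lies beyond the scatter. Within the data shown here, none of the measured compounds carries a plain chain here, so the size of the step remains uncertain. With compound 1 and compound 2 both higher than compound 3, a modest rise in this assay is expected. The estimated step is a number 0.47 log units higher from compound 3 to compound 4 (beyond the scatter) and would be upward. Compound 4 is expected to read about 3.7 within an estimated range of 3.2 to 4.2 in this measurement.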

Compound 4, partition coefficient: 3.26
The estimate for compound 4 lay 0.44 log units above the measured number; the range from low to high includes it.
By their numbers in this assay, from the lowest: compounds 3 and 4 (each within the scatter of the next); then compound 2; then compound 1.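

In this assay the change from ring to chain at this place gives a number 0.03 log units higher from compound 3 to compound 4 (within the scatter), so pentyl, with no ring, and 3,5-difluorophenyl, with its aromatic ring, cannot be told apart on a saturated chain carbon bound to an aromatic nitrogen. Against the other two aryl groups the same chain gives a number 0.63 log units lower from compound 2 to compound 4 (beyond the scatter) and a number 1.06 log units lower from compound 1 to compound 4 (beyond the scatter), which shows that a ring at this place does not by itself set the number, since the two ring-bearing compounds and compound 3 sit at different levels. No measurement at hand offers a reason for the match between compound 3 and compound 4.

Only one plain chain appears here, so the compounds shown cannot tell whether the number follows chain length. A longer chain such as octyl, or a chain ending in an amine or a carboxylic acid, remains an open case at this place.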